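Phenyl for furan on the shared core

The source may hold more compounds than are shown below. What is called first, only, known or untested is meant among the compounds shown, and "the series" means these compounds.

Compound 2 `COc1ccc(N2C[C@@H](C)N[C@@H](C)C2)cc1NS(=O)(=O)c1cccc(-c2ccco2)c1` and compound 1 `COc1ccc(N2C[C@@H](C)N[C@@H](C)C2)cc1NS(=O)(=O)c1ccc(-c2cccs2)cc1` share the same core and differ in the aromatic group attached to the sulfonamide ring. In a functional assay for agonist activity at growth hormone secretagogue receptor type 1 (Homo sapiens), read by FLIPR (on this read-out lower numbers stand for an effect already at smaller amounts and higher numbers for an effect only at larger amounts of compound), compound 1 gives 3.98 nM, whereas compound 2 gives 20 nM. Going by the values given here, compound 2 therefore stands at the highest of the two numbers so far, with compound 1 as its only neighbour at a lower number, and that gap lies beyond the usual scatter. The two compounds are not joined by a single change, so their two values can only be set side by side.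

Compound 3 `COc1ccc(N2C[C@@H](C)N[C@@H](C)C2)cc1NS(=O)(=O)c1cccc(-c2ccccc2)c1` differs from compound 2 in one place: phenyl in place of furan-2-yl on an aromatic carbon. Both groups are aromatic, and the change is small in what it removes and adds. Among the compounds with values here, no measured pair shows such a change on this core, so the direction cannot be read from the data. Compound 3 is estimated to lie at 15 nM, within 5 nM to 50 nM, and the step of a 1.3-fold lower number from compound 2 to compound 3 (0.12 log units; within the scatter) is expected to stay within the scatter.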

Compound 3, half-maximal effective concentration: 158 nM
The estimate for compound 3 lay 11-fold (1.02 log units) below the measured number; measured number outside the range, above it.
By their numbers in this assay, from the lowest: compound 1; then compound 2; then compound 3.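

In this assay, exchanging one aromatic ring for another at this place, on an aromatic carbon meta to a large group, is not a neutral change: phenyl in place of furan-2-yl gives a 7.9-fold higher number from compound 2 to compound 3 (0.90 log units; beyond the scatter). The position therefore distinguishes between these two groups, although both are aromatic, carry no net charge and have no hydrogen-bond donors, and the entering group differs from the leaving one by a six-membered ring of carbon only and the loss of the single hydrogen-bond acceptor. No available evidence accounts for the rise in the number, so the step stands as an observation only.

The compounds shown leave open whether the ring size or the ring oxygen of furan-2-yl carries this step, a question on which a pyridine ring or a cyclopentyl group on the same carbon would bear. They also leave open whether furan-2-yl and phenyl would differ in the same direction and by a similar size if placed where compound 1 carries its thiophene ring.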